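Oxan-4-yl for 2-hydroxyethyl on a shared core

A few compounds are considered here, and "the series" means these few. Any claim that something is new, unique, unknown or untested is made for them only; others in the source may bear on it.

Measured so far:
compound 1 `COc1ccc(Cn2c(-c3ccccc3)c(-c3ccccc3)c3c(=N)n(CCO)cnc32)cc1` — 2830 nM; 2820 nM (2 entries)
compound 2 `COc1ccc(-c2c(-c3ccc(OC)cc3)n(Cc3ccccc3)c3ncn(CCO)c(=N)c23)cc1` — > 20000 nM

In a functional assay on PC-3M cells (Homo sapiens) for antiproliferative activity, read by microscopy, with a stated time of 24 h (on this read-out lower numbers stand for stronger inhibition and higher numbers for weaker inhibition), compound 1 gives 2830 nM; 2820 nM (2 entries), with its repeat entries lying close together (the several entries of compound 1 in this assay, 2830 nM; 2820 nM (2 entries)). Compound 2 reaches only a limit of the assay, > 20000 nM, so no single number stands for it (the limit of > 20000 nM in this assay, at which 1 of the 2 values shown sits). The two compounds differ in more than one place, so their values are set side by side without a step between them; what they show is that compound 1 gives a number and compound 2 does not.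

Compound 3 `COc1ccc(-c2c(-c3ccc(OC)cc3)n(Cc3ccccc3)c3ncn(C4CCOCC4)c(=N)c23)cc1` is not yet measured. It differs from compound 2 in one place: oxan-4-yl in place of 2-hydroxyethyl on an aromatic nitrogen. Going by the values given here, no step between measured compounds is available to calibrate this change. Given that compound 2 sits at the limit, compound 3 is expected to move little, and most likely to remain at or close to that limit rather than to shift beyond the scatter in either direction. Compound 3 is therefore estimated at 30000 nM, with a range of 8000 nM to 100000 nM; the expected step is a step that the limit leaves unreadable from compound 2 to compound 3.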

Compound 3, half-maximal inhibitory concentration: > 20000 nM
Compound 3: a limit, no number; the forecaster's own chance of this, stated with the estimate: 70%; the middle value does not contradict the limit.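

In this assay compound 2 gives > 20000 nM, which is a limit and not a number. Compound 3 gives > 20000 nM, also a limit, so no step can be read between compound 2 and compound 3. The compounds shown leave open what oxan-4-yl in place of 2-hydroxyethyl does to the value when both partners give a number.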